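The compounds below may be only part of what the source reports. "The series", "measured", "known", "first", "only" and "open" are said of these compounds alone.

Working notes on the series, read in a functional assay on DU-145 cells (Homo sapiens) for antiproliferative activity, read by sulforhodamine B assay, with a stated time of 3 days; on this read-out higher numbers stand for weaker inhibition of growth and lower numbers for stronger inhibition of growth. Compound 2 `O=C(c1cccc(Nc2ncc(F)c(Nc3ccc(F)cc3)n2)c1)N1CCCCC1` gives 13000 nM, and compound 1 `O=C(Nc1ccccn1)c1cccc(Nc2ncc(F)c(Nc3ccc(F)cc3)n2)c1` gives 15100 nM. Compound 3 `O=C(Nc1cccc(Nc2ncc(F)c(Nc3ccc(F)cc3)n2)c1)c1ccccc1` gives > 10000 nM, which is a limit. The steps to compound 3 give no size: a step that the limit leaves unreadable from compound 1 to compound 3 and a step that the limit leaves unreadable from compound 2 to compound 3.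

Compound 4 `COc1cc(NC(=O)c2cccc(Nc3ncc(F)c(Nc4ccc(F)cc4)n3)c2)cc(OC)c1` differs from compound 2 by (3,5-dimethoxyphenyl)amino in place of piperidin-1-yl on a carbonyl carbon, with (3,5-dimethoxyphenyl)amino in place of piperidin-1-yl on a carbonyl carbon. Going by the values given here, the one readable step at that carbonyl carbon is a 1.2-fold lower number from compound 1 to compound 2 (0.07 log units; within the scatter), so no step beyond the scatter is expected in this assay. The expected change is a 1.1-fold lower number from compound 2 to compound 4 (0.03 log units; within the scatter). Compound 4 is estimated at 12000 nM, with an expected range from 5000 nM to 30000 nM.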

Compound 4, concentration for 50% growth inhibition: 13700 nM
Beside the measured number, compound 4's estimate is 1.1-fold (0.06 log units) below it, within the range that was stated.
By their numbers in this assay, from the lowest: compounds 2, 4 and 1 (each within the scatter of the next).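

Within this assay, (3,5-dimethoxyphenyl)amino in place of piperidin-1-yl on the carbonyl carbon gives a 1.1-fold higher number from compound 2 to compound 4 (0.02 log units; within the scatter). On the amide-type nitrogen, 3,5-dimethoxyphenyl in place of pyridin-2-yl gives a 1.1-fold lower number from compound 1 to compound 4 (0.04 log units; within the scatter). A methoxy-bearing phenyl ring at this place thus joins piperidin-1-yl and (pyridin-2-yl)amino with all three compounds within the scatter of one another, so no group here stands apart.

On these data alone, whether a basic amine or a carboxylic acid at this place would give a step beyond the scatter stays open. Compound 3 is a limit, and its steps cannot be read: the limit of > 10000 nM in this assay, at which 1 of the 4 values shown sits.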